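The source may report more compounds than this note shows. Statements on the series, on what has been measured and on what is new or still open speak of the compounds shown alone.

In a functional assay on MCF7 cells (Homo sapiens) for inhibition, read by sulforhodamine B assay, with a stated time of 48 h (on this read-out lower numbers stand for stronger inhibition of growth and higher numbers for weaker inhibition of growth), compound 3 (`O=C(CCl)NC(=O)Nc1ccc(Oc2ccccc2)cc1`) gives 4200 nM. That sits within the usual scatter of compound 2 (`O=C(CCl)NC(=O)Nc1ccc(OC2CCCCCC2)cc1`), which gives 3600 nM, so the two cannot be told apart. Compound 1 (`c1ccc(COc2ccc(NC3=NCCO3)cc2)cc1`) has a different core and gives 11100 nM, a number beyond the scatter from both and therefore weaker inhibition of growth.

The next compound, compound 4 (`O=C(CCl)NC(=O)Nc1ccc(OCc2ccccc2)cc1`), keeps the core of compound 3 and changes one group: benzyl in place of phenyl on an oxygen on an aromatic ring, (benzyl in place of phenyl on an oxygen on an aromatic ring).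

Within the data shown here, only one measured step touches that oxygen substituent within this core: a 1.2-fold higher number from compound 2 to compound 3 (0.07 log units; within the scatter). That swap, between a cycloheptyl and a phenyl, left the number within the scatter. Among the measured compounds shown here, compound 1 also carries a benzyl on an oxygen, but its core differs in more than one place, so it offers no clean step. For the measured compounds named here, no measurement yet shows what benzyl does on the core of compound 3.

On this single small step, no change beyond the scatter is expected, and the expected step is a 1.1-fold lower number from compound 3 to compound 4 (0.04 log units; within the scatter). The estimate for compound 4 is 3800 nM, with an expected range of 1800 nM to 8000 nM.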

Compound 4, concentration for 50% growth inhibition: 4600 nM
Estimate against measurement, compound 4: 1.2-fold (0.08 log units) below, and the stated range covers the measured number.
By their numbers in this assay, from the lowest: compounds 2, 3 and 4 (each within the scatter of the next); then compound 1.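

The oxygen substituent on this core has now been tested with three groups, and in this assay the step from phenyl to benzyl is a 1.1-fold higher number from compound 3 to compound 4 (0.04 log units; within the scatter), while the step from cycloheptyl to benzyl is a 1.3-fold higher number from compound 2 to compound 4 (0.11 log units; within the scatter). Both steps stay within the scatter, so cycloheptyl, phenyl and benzyl cannot be told apart at this position, even though the ring is non-aromatic in one group and aromatic in the other two. Among these compounds, compound 4 also shares its benzyl on oxygen with compound 1, which for the first time gives a clean view of the other end of the molecule: on the nitrogen on an aromatic ring, the open chlorine-containing group in place of the five-membered non-aromatic ring gives a 2.4-fold lower number from compound 1 to compound 4 (0.38 log units; beyond the scatter), a modest move towards stronger inhibition of growth.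

Nothing available here accounts for either the flat response at the oxygen or the step at the nitrogen. Still open, from the compounds shown here alone, is whether an amine, a carboxylic acid or a longer chain on that oxygen would finally move the number beyond the scatter, and how much of the step at the nitrogen depends on the chlorine itself.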